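Phenyl in place of thiophen-3-yl on the shared core

A few compounds are considered here, and "the series" means these few. Any claim that something is new, unique, unknown or untested is made for them only; others in the source may bear on it.

Measured so far:
compound 1 (`CC(C)(O)c1cc2c(-c3ccc(-c4ccccc4)c(F)c3)nccc2[nH]1`) at 9100 nM
compound 2 (`CC(C)(O)c1cc2c(-c3ccsc3)nccc2[nH]1`) at 199000 nM

Both numbers come from an ADME assay on U2OS cells (Homo sapiens) for cytotoxicity (on this read-out higher numbers stand for lower toxicity in this test and lower numbers for higher toxicity in this test), and are the only ones available. Compound 2 at 199000 nM stands highest of the two, beyond the scatter from compound 1. The next compound to be measured is compound 3 (`CC(C)(O)c1cc2c(-c3ccccc3)nccc2[nH]1`), which carries phenyl in place of thiophen-3-yl on an aromatic carbon, next to the ring nitrogen (phenyl in place of thiophen-3-yl on an aromatic carbon). Among the compounds with values here, no measured pair shows this exchange, so the data offer no direct step for it. The expectation therefore starts from compound 2 at 199000 nM as the closest measured structure. The estimated step of a 1.7-fold lower number from compound 2 to compound 3 (0.22 log units; within the scatter) is expected to stay within the scatter, if anything toward a lower number. Compound 3 is estimated at 120000 nM in this assay with a range of 50000 nM to 250000 nM expected to hold the measurement.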

Compound 3, half-maximal cytotoxic concentration: 22200 nM
Compound 3: middle estimate off by 5.4-fold (0.73 log units), on the high side; the measured number lies below the stated range.
By their numbers in this assay, from the lowest: compound 1; then compound 3; then compound 2.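

In this assay, within the data shown here, placing phenyl instead of thiophen-3-yl on this aromatic carbon, next to the ring nitrogen, gives a 9.0-fold lower number from compound 2 to compound 3 (0.95 log units; beyond the scatter), the first step that can be read at a single place. It shows that the group held at this carbon is enough by itself to move the read-out beyond the scatter, with phenyl giving the higher toxicity in this test. No supporting data bear on why this exchange has an effect of this size.

From the compounds shown here alone, it remains open whether an amine or a carboxylic acid on the phenyl ring would bring the number back toward that of compound 2. Also open, going by these compounds, is whether thiophen-2-yl or pyridin-3-yl at this carbon would behave more like thiophen-3-yl or more like phenyl.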